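The source may report more compounds than this note shows. Statements on the series, on what has been measured and on what is new or still open speak of the compounds shown alone.

Working notes on the series in a functional assay on HeLa cells (Homo sapiens) for inhibition, read by MTT assay, with a stated time of 72 h; on this read-out higher numbers stand for weaker inhibition and lower numbers for stronger inhibition: compound 1 (`COc1ccc(-c2nnc(SCCCN3CCN(c4nc5ccccc5o4)CC3)o2)cc1`) gives 210000 nM, compound 2 (`Clc1ccc(-c2nnc(SCCCN3CCN(c4nc5ccccc5o4)CC3)o2)cc1`) gives 101000 nM and compound 3 (`Clc1ccc(-c2nnc(SCCCN3CCN(c4nc5ccccc5s4)CC3)o2)cc1`) gives 177000 nM. Compound 3 holds the second highest of the three numbers, yet it lies within the scatter of both compound 1 and compound 2.

Compound 4 (`c1ccc(-c2nnc(SCCCN3CCN(c4nc5ccccc5s4)CC3)o2)cc1`) carries hydrogen in place of chloro on an aromatic carbon. Going by the values given here, no measured pair removes a chloro for hydrogen. The closest evidence is a 2.1-fold lower number from compound 1 to compound 2 (0.32 log units; beyond the scatter), with chloro in place of methoxy at the same kind of carbon, a modest step just beyond the scatter. The other measured step, a 1.8-fold higher number from compound 2 to compound 3 (0.24 log units; within the scatter), changes a different place and stays within the scatter.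

Among the compounds with values here, with only this evidence, no step beyond the scatter is expected in this assay, and no direction can be favoured. The expected change is a 1.0-fold lower number from compound 3 to compound 4 (0.02 log units; within the scatter). For compound 4 the estimated value is 170000 nM, with an expected range of 90000 nM to 320000 nM.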

Compound 4, half-maximal inhibitory concentration: 229000 nM
Estimate against measurement, compound 4: 1.3-fold (0.13 log units) below, within the range that was stated.
By their numbers in this assay, from the lowest: compounds 2, 3, 1 and 4 (each within the scatter of the next, the first and the last beyond it).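

In this assay, going by these compounds alone, the first direct reading of chloro against hydrogen on this aromatic carbon, para to a large group, is a 1.3-fold higher number from compound 3 to compound 4 (0.11 log units; within the scatter), so the change from 4-chlorophenyl to phenyl does not separate the two compounds. Until now, this carbon had been read only through a 2.1-fold lower number from compound 1 to compound 2 (0.32 log units; beyond the scatter), a step that replaces methoxy with chloro on the 1,3-benzoxazol-2-yl compounds; the new step adds the unsubstituted phenyl, read on a 1,3-benzothiazol-2-yl compound. No measurement available here offers an explanation for this result.

Going by these compounds, whether the same change from 4-chlorophenyl to phenyl would stay within the scatter on a 1,3-benzoxazol-2-yl compound remains open. Also open, on these data alone, is how a carboxylic acid, an amine or a nitrile on this carbon would read against hydrogen and chloro.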